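The compounds below may be only part of what the source reports. "The series", "measured", "known", "first", "only" and "open" are said of these compounds alone.

Compound 1 `c1ccc(-c2cnoc2)c(NCC2=NCCN2)c1` and compound 2 `CO/N=C(\C)c1ccccc1NCC1=NCCN1` were both run in a functional assay for activation of Alpha-1B adrenergic receptor (Homo sapiens), read by calcium flux; on this read-out higher numbers stand for an effect only at larger amounts of compound and lower numbers for an effect already at smaller amounts. In this assay compound 1 gives < 100000 nM, which is a limit of the assay and not a number. In this assay compound 2 likewise gives only a limit, < 5020 nM. The step that the two limits leave unreadable from compound 1 to compound 2 therefore stays unreadable, as the limit of < 100000 nM in this assay, at which 1 of the 2 values shown sits, and the limit of < 5020 nM in this assay, at which 1 of the 2 values shown sits, make plain. Compound 3 `CCO/N=C(\C)c1ccccc1NCC1=NCCN1` differs from compound 2 by methyl in place of hydrogen on a saturated chain carbon bound to an oxygen on an unsaturated carbon. For the measured compounds named here, no measured step touches this change, so no shift beyond the scatter is expected, estimated as a step that the limit leaves unreadable from compound 2 to compound 3. For compound 3 the expected value in this assay is 2000 nM, within 300 nM to 10000 nM.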

Compound 3, half-maximal effective concentration: < 5020 nM
Compound 3 gave a limit, no number; the forecaster's own chance of this, stated with the estimate: 50%; the middle value does not contradict the limit.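

For the compounds shown here, compound 1, compound 2 and compound 3 each give only a limit in this assay, so no step among them can be read. The compounds shown leave open what shift, if any, methyl in place of hydrogen brings.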